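This account rests on a few compounds, and the source may have more. Where it says the series, first, only, none or still open, it means among the compounds named here.

Measured so far:
compound 1 `COc1ccccc1C(=O)Nc1cccc(-c2oc3cc(-c4ccc(F)cc4)ccc3c(=O)c2O)c1` — 6370 nM in a functional assay on GTL 16 cells for antiproliferative activity against GTL 16 cell line (Homo sapiens), read by CCK-8 assay, with a stated time of 72 h; on this read-out higher numbers stand for weaker inhibition and lower numbers for stronger inhibition
compound 2 `O=C(Nc1cccc(-c2oc3cc(-c4ccc(F)cc4)ccc3c(=O)c2O)c1)c1ccc(Br)cc1` — 25400 nM in this assay

Compound 2 gives the highest of the two numbers; its nearest neighbour is compound 1, reached by a 4.0-fold higher number from compound 1 to compound 2 (0.60 log units; beyond the scatter). Compound 3 `COc1ccc(C(=O)Nc2cccc(-c3oc4cc(-c5ccc(F)cc5)ccc4c(=O)c3O)c2)c(F)c1` carries 2-fluoro-4-methoxyphenyl in place of 4-bromophenyl on a carbonyl carbon. Among the measured compounds shown here, only that single step bears on this change, and only loosely, through the methoxy shared with compound 1; no step tests the fluorine. For compound 3 the expected step is a 2.3-fold lower number from compound 2 to compound 3 (0.36 log units; beyond the scatter), a partial return toward compound 1. Compound 3 is therefore estimated at 11000 nM, within 3500 nM to 35000 nM.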

Compound 3, half-maximal inhibitory concentration: 15300 nM
Compound 3: the middle estimate sits 1.4-fold (0.14 log units) below what was measured, and the stated range covers the measured number.
By their numbers in this assay, from the lowest: compound 1; then compounds 3 and 2 (each within the scatter of the next).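

In this assay, a 1.7-fold lower number from compound 2 to compound 3 (0.22 log units; within the scatter) shows that 2-fluoro-4-methoxyphenyl and 4-bromophenyl on this carbonyl carbon are not told apart. a 2.4-fold higher number from compound 1 to compound 3 (0.38 log units; beyond the scatter), so with both steps from compound 1 now beyond the scatter, compound 1 holds the lowest number of the three. No measurement on hand bears on the reason for these steps.

Among the compounds shown here, no step separates the fluorine from the methoxy in compound 3. Also open, on these data alone, is how an unsubstituted phenyl, or an amine or carboxylic acid on the phenyl, would read here.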